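The compounds below may be only part of what the source reports. "The series", "measured", "known", "first", "only" and "open" are said of these compounds alone.

Of the compounds shown here, three built on one shared core have been tested in a functional assay on BXPC-3 cells (Homo sapiens) for inhibition, read by MTT assay, with a stated time of 7 days; a lower number here means a stronger inhibitor, a higher number a weaker inhibitor. Compound 1 `CCN(CC)S(=O)(=O)c1ccc(S(=O)(=O)N2CCC[C@@H](C(=O)NC3CN(C(=O)OC(C)(C)C)C3)C2)cc1` gives 1800 nM, compound 2 `CCN(CC)S(=O)(=O)c1ccc(S(=O)(=O)N2CCC[C@@H](C(=O)NC3CN(C(=O)C4CC4)C3)C2)cc1` gives 18500 nM, and compound 3 `CCN(CC)S(=O)(=O)c1ccc(S(=O)(=O)N2CCC[C@@H](C(=O)NC3COC3)C2)cc1` gives 13800 nM. Among these three numbers compound 3 stands second highest: the gap a 1.3-fold lower number from compound 2 to compound 3 (0.13 log units; within the scatter) lies within the scatter, whereas the step of a 7.7-fold higher number from compound 1 to compound 3 (0.88 log units; beyond the scatter) lies beyond it. The remaining measured step, a 10-fold higher number from compound 1 to compound 2 (1.01 log units; beyond the scatter), shows that swapping tert-butoxy for cyclopropyl on the carbonyl carbon also raised the number.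

Compound 4 `CCN(CC)S(=O)(=O)c1ccc(S(=O)(=O)N2CCC[C@@H](C(=O)N[C@H]3CCN(C(=O)OC(C)(C)C)C3)C2)cc1` has not yet been measured. It differs from compound 3 in a single place 1-(tert-butoxycarbonyl)pyrrolidin-3-yl in place of oxetan-3-yl on an amide-type nitrogen and so again carries a ring bearing a tert-butoxycarbonyl group, as compound 1 does, though a five-membered rather than a four-membered one. Among the compounds with values here, the step that bears most directly on this change is the one between compound 1 and compound 3, because a 7.7-fold higher number from compound 1 to compound 3 (0.88 log units; beyond the scatter) describes the reverse swap, a tert-butoxycarbonyl-bearing ring giving way to oxetan-3-yl. A step of roughly that size, towards a lower number, is therefore expected, namely a 5.5-fold lower number from compound 3 to compound 4 (0.74 log units; beyond the scatter). Compound 4 is estimated at 2500 nM, with a likely range from 800 nM to 8000 nM.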

Compound 4, half-maximal inhibitory concentration: 300 nM
Compound 4: middle estimate off by 8.3-fold (0.92 log units), on the high side; measured number below the stated range.
By their numbers in this assay, from the lowest: compound 4; then compound 1; then compounds 3 and 2 (each within the scatter of the next).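

In this assay, the new result shows that the tert-butoxycarbonyl group does not set the number at this amide-type nitrogen by itself: with that group kept, replacing 1-(tert-butoxycarbonyl)azetidin-3-yl with 1-(tert-butoxycarbonyl)pyrrolidin-3-yl gives a 6.0-fold lower number from compound 1 to compound 4 (0.78 log units; beyond the scatter), a change that combines a four-membered ring giving way to a five-membered one with a defined stereocentre entering. The same group also widens the span seen at this position, with a 46-fold lower number from compound 3 to compound 4 (1.66 log units; beyond the scatter) when it replaces oxetan-3-yl and a 62-fold lower number from compound 2 to compound 4 (1.79 log units; beyond the scatter) when it replaces 1-(cyclopropylcarbonyl)azetidin-3-yl. No evidence is available on what lies behind these steps.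

The compounds shown cannot separate the effect of ring size from that of the stereocentre, and they leave open how the mirror-image form of the 1-(tert-butoxycarbonyl)pyrrolidin-3-yl group would compare. From the compounds shown here alone, it also remains open whether the low number needs the tert-butoxycarbonyl group at all, or whether a five-membered ring carrying a cyclopropylcarbonyl group, or a free amine at the ring nitrogen, would give a similar value.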